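This account rests on a few compounds, and the source may have more. Where it says the series, first, only, none or still open, it means among the compounds named here.

Compound 1 `Cc1[nH]c(=O)n(C)c1-c1ccccc1` — > 100000 nM
Compound 2 `CCCCc1ccc(-c2c(C)[nH]c(=O)n2C2CCCCC2)cc1` — 27100 nM

In a functional assay on brain (Rattus norvegicus, strain Wistar) for inhibition (on this read-out higher numbers stand for weaker inhibition and lower numbers for stronger inhibition), compound 1 gives > 100000 nM, which is a limit of the assay and not a number. Compound 1 therefore stands at the limit of > 100000 nM in this assay, at which 1 of the 2 values shown sits, the weaker end of what has been seen. In this assay compound 2, which carries a butyl chain and a cyclohexyl group, gives 27100 nM. Compound 3 `CCCCCOc1ccc(-c2c(C)[nH]c(=O)n2C)cc1` has not yet been measured in this assay. It differs from compound 1 by pentyloxy in place of hydrogen on an aromatic carbon. No pair of measured compounds differs in one place, so the size of such a step is not shown directly. A moderate step toward stronger inhibition is nevertheless expected, as an at least 2.5-fold lower number from compound 1 to compound 3 (0.39 log units; beyond the scatter), because compound 2 gives 27100 nM in this assay while carrying a chain of similar length. For compound 3 the expected value in this assay is 40000 nM, with a range from 10000 nM to 150000 nM.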

Compound 3, half-maximal inhibitory concentration: 4500 nM
For compound 3 the middle estimate is 8.9-fold (0.95 log units) above the measured one; the whole stated range lies above it.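

In this assay, pentyloxy in place of hydrogen on an aromatic carbon, para to a group of 8 heavy atoms, gives an at least 22-fold lower number from compound 1 to compound 3 (1.34 log units; beyond the scatter). Going by these compounds alone, this is the first single change whose size can be read, and it shows that this position of the six-membered aromatic ring tolerates the added chain and that the change is large. The step can be given only as a minimum, because its starting point at compound 1 is a limit of the assay and not a number: the limit of > 100000 nM in this assay, at which 1 of the 3 values shown sits.

The compounds shown leave open whether the step comes from the oxygen or from the chain, a question that a plain pentyl group, a shorter methoxy group or a longer octyloxy chain could address. Also open, going by these compounds, is how an amine or a carboxylic acid in place of the pentyloxy would read in this assay.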